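Three Sulfonamides at the Limit, a Dichlorophenyl Next

This account rests on a few compounds, and the source may have more. Where it says the series, first, only, none or still open, it means among the compounds named here.

Compound 1 `O=S(=O)(Nc1ccc(-c2nc3ccccc3o2)cc1)c1ccc(Cl)s1`, compound 2 `C=Cc1ccc(S(=O)(=O)Nc2ccc(-c3nc4ccccc4o3)cc2)cc1` and compound 3 `COc1cccc(S(=O)(=O)Nc2ccc(-c3nc4ccccc4o3)cc2)c1` share one core and differ only in the group on the sulfonyl sulfur. In an assay on isolated protein for inhibition of malate dehydrogenase, mitochondrial (Sus scrofa), with stated times of 45 min and 30 min (a higher number here means a weaker inhibitor, a lower number a stronger inhibitor), compound 1 gives > 63000 nM, which is a limit of the assay and not a number. Compound 2 gives > 63000 nM in this assay, again a limit. Compound 3 gives > 63000 nM in this assay, also a limit. Compound 3 thus stands at the limit together with the other two (the limit of > 63000 nM in this assay, at which 3 of the 3 values shown sit). The steps a step that the two limits leave unreadable from compound 1 to compound 2, a step that the two limits leave unreadable from compound 1 to compound 3 and a step that the two limits leave unreadable from compound 2 to compound 3 cannot be sized, since both ends of each sit at the limit. Compound 4 `O=S(=O)(Nc1ccc(-c2nc3ccccc3o2)cc1)c1ccc(Cl)c(Cl)c1` arises from compound 3 through (3,4-dichlorophenyl in place of 3-methoxyphenyl on a sulfonyl sulfur). The two steps that end at compound 3 also swap the group on the sulfonyl sulfur. Neither gave a readable size, so no gain can be expected from them. The expected size of the step is a step that the limit leaves unreadable from compound 3 to compound 4, meaning compound 4 is also expected to sit at the limit. Compound 4 is expected to give about 100000 nM in this assay, with a range from 30000 nM to 500000 nM.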

Compound 4, half-maximal inhibitory concentration: > 63000 nM
Compound 4: only a limit was reported; the forecaster's own chance of this, stated with the estimate: 80%; the middle value lies beyond the limit too.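

In this assay compound 4 gives > 63000 nM, which is a limit of the assay and not a number. Its steps from compound 1, compound 2 and compound 3 cannot be read, since both ends of each sit at a limit: the limit of > 63000 nM in this assay, at which 4 of the 4 values shown sit. The compounds shown leave open which group on the sulfonyl sulfur, if any, would give a readable value.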